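This account rests on a few compounds, and the source may have more. Where it says the series, first, only, none or still open, it means among the compounds named here.

Compound 1 `COc1ccc2[nH]c(C(=O)N3CC(=O)N(Cc4ccccc4)[C@@H](CN4CCCCC4)C3)cc2c1` carries a benzyl group and a (piperidin-1-yl)methyl group on the shared core. Among the measured compounds shown here, in an ADME assay on Vero cells (Chlorocebus sabaeus) for cytotoxicity, with a stated time of 7 days (on this read-out lower numbers stand for higher toxicity in this test and higher numbers for lower toxicity in this test), compound 1 gives 76900 nM, the only plain number among the two values known here. Compound 2 `COc1cccc(CN2C(=O)CN(C(=O)c3cc4cc(OC)ccc4[nH]3)C[C@@H]2c2ccccc2)c1` gives > 10000 nM in this assay, which is a limit of the assay and not a number, as described by the limit of > 10000 nM in this assay, at which 1 of the 2 values shown sits. For the measured compounds named here, no two measured compounds differ in a single place, so no measured step sets a scale for what one small change does in this test. Compound 3 `COc1ccc2[nH]c(C(=O)N3CC(=O)N(Cc4ccccc4)[C@@H](CN4CCC(C(C)C)CC4)C3)cc2c1` differs from compound 1 by isopropyl in place of hydrogen on a saturated ring carbon. Going by the values given here, with no measured step to lean on, the step in this assay is expected to be modest, most likely toward somewhat higher toxicity, though it may stay within the usual scatter. Compound 3 is expected to give 40000 nM in this assay, between 15000 nM and 100000 nM. That estimate corresponds to an expected step of a 1.9-fold lower number from compound 1 to compound 3 (0.28 log units; within the scatter).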

Compound 3, half-maximal cytotoxic concentration: 3800 nM
Compound 3: the middle estimate sits 11-fold (1.02 log units) above what was measured; measured number outside the range, below it.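

In this assay, among the compounds shown here, going from piperidin-1-yl to 4-isopropylpiperidin-1-yl gives a 20-fold lower number from compound 1 to compound 3 (1.31 log units; beyond the scatter), the first measured step. This saturated ring carbon, three ring bonds from the ring nitrogen, is therefore a place where adding an isopropyl group matters a great deal, and since a lower number stands for higher toxicity in this test, compound 3 is the more toxic of this pair. Nothing shown here explains why this one change has so large an effect.

With isopropyl as the only group shown on this carbon, it remains open whether a methyl, a hydroxyl or a carboxylic acid there would give a number closer to that of compound 1 or of compound 3. A single step also leaves open whether isopropyl would have a similar effect if the benzyl group were replaced by another group.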